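Methyl for hydrogen on the chain carbon in two pairs

This account rests on a few compounds, and the source may have more. Where it says the series, first, only, none or still open, it means among the compounds named here.

Measured so far:
compound 1, `CC(C(=O)N1CCN(c2ccc(C(F)(F)F)cc2)CC1)N1C(=O)CCC1=O` — in a functional assay on the whole organism (strain Swiss) with Mus musculus as the target, in the maximal electroshock model, with a stated time of 0.5 h, at a dose of 300 mg/kg by the intraperitoneal route (on this read-out higher numbers stand for a stronger effect at the one dose given and lower numbers for a weaker effect), compound 1 gives 25%
compound 2, `CCC(C(=O)N1CCN(c2ccc(C(F)(F)F)cc2)CC1)N1C(=O)CCC1=O` — compound 2 gives 0%
compound 3, `CC(C(=O)N1CCN(c2ccccc2C(F)(F)F)CC1)N1C(=O)CCC1=O` — compound 3 gives 100%

Compounds 1 and 2 share one core. Compound 2 differs from compound 1 by methyl in place of hydrogen on a saturated chain carbon, two bonds along the chain from an amide-type nitrogen in a ring and a carbonyl carbon, and that change gives a number 25 percentage points lower from compound 1 to compound 2 (beyond the scatter). Compound 3 is built from the same atoms as compound 1, joined differently; the difference between the two cores is not broken down here. Among the three measured compounds, compound 3 stands highest, with the step to each of the other two beyond the scatter.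

Compound 4, `CCC(C(=O)N1CCN(c2ccccc2C(F)(F)F)CC1)N1C(=O)CCC1=O`, has not been measured. It differs from compound 3 by methyl in place of hydrogen on a saturated chain carbon, two bonds along the chain from an amide-type nitrogen in a ring and a carbonyl carbon; the place of the change is the same as in the pair of compounds 1 and 2, so this is the same change applied to the core of compound 3. Within the data shown here, only one earlier instance of the change is available, and it was measured from a low starting number, so how much of the effect of compound 3 survives is uncertain. The expectation is a fall of about a number 45 percentage points lower from compound 3 to compound 4 (beyond the scatter), resting on the loss seen in a number 25 percentage points lower from compound 1 to compound 2 (beyond the scatter), with compound 3 starting from 100% leaving more room to fall. Compound 4 is therefore expected to give about 55%, estimated to lie between 10% and 100%.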

Compound 4, a percentage reported as activity, at one dose (the size of the read-out at that dose, not a potency): 25%
For compound 4 the middle estimate is 30 percentage points above the measured one; measured number inside the range.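

In this assay, methyl in place of hydrogen on the chain carbon lowers the number on both cores, here with a number 75 percentage points lower from compound 3 to compound 4 (beyond the scatter), but the size of the fall does not carry over: the same change on two cores in this assay, a number 25 percentage points lower (beyond the scatter) from compound 1 to compound 2 and a number 75 percentage points lower (beyond the scatter) from compound 3 to compound 4, 50 percentage points apart, beyond the scatter of two such steps The direction holds in both pairs, while the smaller step starts from compound 1 at 25% and ends at compound 2 at 0%, the bottom of this read-out, so the room to fall differs between the two cores and the true gap in effect may be wider than the numbers can show. Two pairs at a single dose and a single time give neither a potency nor a rule for other cores, and they do not show why the size of the step differs.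

Going by these compounds, it remains open whether a propyl chain or a hydroxymethyl group on the same saturated chain carbon would lower the number as far as the methyl does on the core of compound 3. Also open, on these data alone, is whether a chloro or methoxy group in place of the trifluoromethyl would keep the number of compound 3, and how large the methyl step would then be.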